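Notes on the amine substituent of the shared core

This account rests on a few compounds, and the source may have more. Where it says the series, first, only, none or still open, it means among the compounds named here.

Values in a functional assay on MCF7 cells (Homo sapiens) for inhibition, read by sulforhodamine B assay; a higher number here means a weaker inhibitor, a lower number a stronger inhibitor:
- compound 1 `O=C1C(Nc2ccc(I)cc2)=CC(=O)c2c1nc1n2[C@H]2OC[C@@H](O)[C@H]2OC1`: 3890 nM
- compound 2 `O=C1C(NC2CCCC2)=CC(=O)c2c1nc1n2[C@H]2OC[C@@H](O)[C@H]2OC1`: > 16000 nM (a limit of the assay)
- compound 3 `CCc1ccc(NC2=CC(=O)c3c(nc4n3[C@H]3OC[C@@H](O)[C@H]3OC4)C2=O)cc1`: 8990 nM

Compound 3 carries the higher of the two exact numbers, at 8990 nM. The next structure for this assay is compound 4 `COc1ccccc1NC1=CC(=O)c2c(nc3n2[C@H]2OC[C@@H](O)[C@H]2OC3)C1=O`, with 2-methoxyphenyl in place of 4-ethylphenyl on an amine nitrogen.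

Within the data shown here, three measured steps bear on this change. Exchanging one para-free description aside, the swap of iodo for ethyl on the aromatic ring gave a 2.3-fold higher number from compound 1 to compound 3 (0.36 log units; beyond the scatter). Leaving the aromatic ring for cyclopentyl gave an at least 4.1-fold higher number from compound 1 to compound 2 (0.61 log units; beyond the scatter), while the return to an aromatic group gave an at least 1.7-fold lower number from compound 2 to compound 3 (0.25 log units; that floor lies within the scatter). Compound 4 keeps a six-membered aromatic ring, as compound 1 and compound 3 do, so the modest step among aryl groups is the closest guide. Going by these compounds, no step beyond the scatter is expected, and the direction stays open. The estimated change is a 1.1-fold lower number from compound 3 to compound 4 (0.05 log units; within the scatter). For compound 4 the expected value is 8000 nM, with an estimated range of 3000 nM to 20000 nM.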

Compound 4, half-maximal inhibitory concentration: 6580 nM
Beside the measured number, compound 4's estimate is 1.2-fold (0.08 log units) above it, within the range that was stated.
By their numbers in this assay, from the lowest: compounds 1, 4 and 3 (each within the scatter of the next, the first and the last beyond it). At a limit, above all of these: compound 2.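

In this assay, 2-methoxyphenyl on the amine nitrogen gives a 1.4-fold lower number from compound 3 to compound 4 (0.14 log units; within the scatter), and the comparison with 4-iodophenyl gives a 1.7-fold higher number from compound 1 to compound 4 (0.23 log units; within the scatter), so compound 4 cannot be separated from either of these aryl compounds, although those two lie beyond the scatter of each other. Against cyclopentyl the change gives an at least 2.4-fold lower number from compound 2 to compound 4 (0.38 log units; beyond the scatter), a floor that clears the scatter, which the floor for 4-ethylphenyl in place of cyclopentyl did not. That step rests on compound 2, whose entry is a limit and not a number: the limit of > 16000 nM in this assay, at which 1 of the 4 values shown sits.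

Compound 3 and compound 4 differ in both the group on the ring and its place, so the two changes remain unseparated until 4-methoxyphenyl can be compared. Also open, going by these compounds, is how an aryl group carrying a carboxylic acid or an amine would stand against compound 1 in this assay.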